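Ethoxycarbonyl in place of propyl: working notes

A few compounds are considered here, and "the series" means these few. Any claim that something is new, unique, unknown or untested is made for them only; others in the source may bear on it.

- compound 1 `COC(=O)NC(CC(=O)N1CCC(Cn2c(C)nc3cnccc32)CC1)c1ccccc1`: 12 nM
- compound 2 `CCCC(CC(=O)N1CCC(Cn2c(C)nc3cnccc32)CC1)c1ccccc1`: 11 nM

In a functional assay (plasma) with Oryctolagus cuniculus as the target (on this read-out lower numbers stand for stronger inhibition and higher numbers for weaker inhibition), compound 2 gives 11 nM, within the scatter of compound 1, so no order separates the two. Compound 3 `CCOC(=O)C(CC(=O)N1CCC(Cn2c(C)nc3cnccc32)CC1)c1ccccc1` has ethoxycarbonyl in place of propyl on a saturated chain carbon bound to an aromatic carbon and a saturated chain carbon. Among the measured compounds shown here, only one measured step bears on this place: a 1.1-fold lower number from compound 1 to compound 2 (0.04 log units; within the scatter), which stays within the scatter. Ethoxycarbonyl itself is untested, and one step is thin evidence. No change beyond the scatter is therefore expected in this assay. The expected result is a 1.4-fold higher number from compound 2 to compound 3 (0.13 log units; within the scatter). For compound 3 the estimated value is 15 nM, with an expected range of 5 nM to 45 nM.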

Compound 3, half-maximal inhibitory concentration: 12 nM
Compound 3: middle estimate off by 1.3-fold (0.10 log units), on the high side, within the range that was stated.
By their numbers in this assay, from the lowest: compounds 2, 1 and 3 (each within the scatter of the next).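

Ethoxycarbonyl on the saturated chain carbon bound to an aromatic carbon and a saturated chain carbon gives a 1.1-fold higher number from compound 2 to compound 3 (0.04 log units; within the scatter) in this assay and also no change at the digits printed from compound 1 to compound 3 (within the scatter) in the same read-out. Three different groups now sit at this place without separating, including a pair that differs from no hydrogen-bond acceptors in propyl to 2 hydrogen-bond acceptors in ethoxycarbonyl. No measurement available here accounts for this flat result.

On these data alone, whether a carboxylic acid, a primary amine or a longer chain at this place would move the number beyond the scatter stays open.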